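Fluorine on the aromatic ring of a trypsin inhibitor series

The compounds below may be only part of what the source reports. "The series", "measured", "known", "first", "only" and "open" are said of these compounds alone.

Measured so far:
- Compound 1, `CS(=O)(=O)c1ccccc1-c1ccc(CC(=O)c2cc(C(F)(F)F)nn2-c2ccc3onc(N)c3c2)c(F)c1`: > 20000 nM
- Compound 2, `COc1ccc(-n2nc(C(F)(F)F)cc2C(=O)Cc2ccc(-c3ccccc3S(N)(=O)=O)cc2)cc1`: > 2500 nM
- Compound 3, `CS(=O)(=O)c1ccccc1-c1ccc(CC(=O)c2cc(C(F)(F)F)nn2-c2ccc3onc(N)c3c2)cc1`: > 20000 nM

Of the compounds shown here, three have been tested in an assay on isolated protein for inhibition of Trypsin (Homo sapiens); on this read-out higher numbers stand for weaker inhibition and lower numbers for stronger inhibition. Compound 3 gives > 20000 nM, which is a limit of this assay and not a number. Compound 1 gives > 20000 nM, again a limit. Compound 2 gives > 2500 nM, also a limit. The step from compound 3 to compound 1 is a step that the two limits leave unreadable from compound 3 to compound 1; with both values sitting at a limit (the limit of > 20000 nM in this assay, at which 2 of the 3 values shown sit), its size cannot be read. The change is fluoro in place of hydrogen on an aromatic carbon.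

Compound 4, `COc1ccc(-n2nc(C(F)(F)F)cc2C(=O)Cc2ccc(-c3ccccc3S(N)(=O)=O)cc2F)cc1`, has not yet been measured. It differs from compound 2 by fluoro in place of hydrogen on an aromatic carbon. This is the same kind of change as that from compound 3 to compound 1; what differs around the place is that the fluoro sits meta to a 2-sulfamoylphenyl group in compound 4 and meta to a 2-(methylsulfonyl)phenyl group in compound 1. The difference between the core of compound 2 and the core of compound 3 is not broken down here.

Among the compounds with values here, compound 2 is known only by a limit (the limit of > 2500 nM in this assay, at which 1 of the 3 values shown sits), and the one measured step of this kind is unreadable, so the expectation for compound 4 rests on weak ground. Compound 4 is expected to give 10000 nM, most likely again as a limit, between 2500 nM and 50000 nM. The expected step from compound 2 to compound 4 is a step that the limit leaves unreadable from compound 2 to compound 4.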

Compound 4, inhibition constant: > 6000 nM
Compound 4 gave a limit, no number (the forecaster's own chance of this, stated with the estimate: 85%); the middle value is on the limit's open side.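

In this assay compound 4 gives > 6000 nM, which is a limit of the assay and not a number. Compound 2 is also known only by a limit, so no size can be read for the step between compound 2 and compound 4. The compounds shown leave open whether fluoro in place of hydrogen on an aromatic carbon changes trypsin inhibition at all, and how strongly any of them inhibits.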